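Fluoro acrylamide step at the carbonyl carbon

The source may hold more compounds than are shown below. What is called first, only, known or untested is meant among the compounds shown, and "the series" means these compounds.

Measured in a functional assay on HeLa cells (Homo sapiens) for antiproliferative activity, read by MTT assay, with a stated time of 72 h; a lower number here means a stronger inhibitor, a higher number a weaker inhibitor:
- compound 1 `C=CC(=O)Nc1cccc(Oc2nc(Nc3cccc(OC)c3)nc3c2CSCC3)c1` gives 28900 nM
- compound 2 `CC/C=C/C(=O)Nc1cccc(Oc2nc(Nc3cccc(OC)c3)nc3c2CSCC3)c1` gives 27200 nM

Not yet measured: compound 3 `C=C(F)C(=O)Nc1cccc(Oc2nc(Nc3cccc(OC)c3)nc3c2CSCC3)c1`.

Within the data shown here, only two compounds have values so far. Compound 2 gives 27200 nM, within the scatter of compound 1, so neither ranks ahead of the other.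

The change from compound 2 to compound 3 is 1-fluoroethenyl in place of but-1-en-1-yl on a carbonyl carbon. In words, it is 1-fluoroethenyl in place of but-1-en-1-yl on a carbonyl carbon, whose other neighbour is an amide-type nitrogen.

Among the measured compounds shown here, one measured step bears on this: a 1.1-fold lower number from compound 1 to compound 2 (0.03 log units; within the scatter). That step also changes the group on the carbonyl carbon, putting but-1-en-1-yl in place of vinyl, and it stays within the scatter. For the measured compounds named here, no compound carrying fluorine has a value yet, so the data offer no direct guide to that part of the change, and the range is kept wide.

No step beyond the scatter is expected in this assay. The expected step is a 1.1-fold lower number from compound 2 to compound 3 (0.04 log units; within the scatter). The estimate for compound 3 is 25000 nM, with an expected range from 11000 nM to 55000 nM.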

Compound 3, half-maximal inhibitory concentration: 44800 nM
Compound 3: middle estimate off by 1.8-fold (0.25 log units), on the low side; the range from low to high includes it.
By their numbers in this assay, from the lowest: compounds 2, 1 and 3 (each within the scatter of the next).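

In this assay, the only fluorine-bearing group shown at this carbonyl carbon stays within the scatter of both other compounds: fluoro in place of hydrogen on a double-bonded chain carbon bound to a carbonyl carbon gives a 1.6-fold higher number from compound 1 to compound 3 (0.19 log units; within the scatter) and 1-fluoroethenyl in place of but-1-en-1-yl gives a 1.6-fold higher number from compound 2 to compound 3 (0.22 log units; within the scatter) in the same read-out. Vinyl, but-1-en-1-yl and 1-fluoroethenyl on a carbonyl carbon whose other neighbour is an amide-type nitrogen are therefore not told apart in this assay, and compound 3 at 44800 nM falls in one band with the other two compounds. No evidence is available on what lies behind any of these steps.

Still open, as far as these compounds go, is whether any group on this carbonyl carbon gives a step beyond the scatter, for example a dimethylaminomethyl group on the double bond, a nitrile in place of the fluoro, or a saturated ethyl chain in place of the vinyl. Also open, from the compounds shown here alone, is whether the fluoro replacement reads the same on a core carrying a carboxylic acid in place of the methoxy group.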